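Adding a Hydroxy to the Chain of Compound 2

A few compounds are considered here, and "the series" means these few. Any claim that something is new, unique, unknown or untested is made for them only; others in the source may bear on it.

Measured compounds:
compound 1 `CC(CCO)n1cnc2c(Cl)nc(F)nc21` — 16800 nM
compound 2 `CC(CCO)n1cnc2c(Cl)ncnc21` — > 50000 nM
compound 3 `CCCCCCCCC[C@@H](CCO)n1cnc2c(Cl)ncnc21` — 3620 nM

In a functional assay on SW480 cells (Homo sapiens) for antiproliferative activity, read by MTT assay, with a stated time of 48 h (on this read-out higher numbers stand for weaker inhibition and lower numbers for stronger inhibition), compound 2 reports only a limit, > 50000 nM, not a number. For the measured compounds named here, the one measured step, an at least 2.9-fold higher number from compound 1 to compound 2 (0.47 log units; beyond the scatter), involved the aromatic fluoro and reached (the limit of > 50000 nM in this assay, at which 1 of the 3 values shown sits). Going by the values given here, compound 3 carries a longer chain and gives 3620 nM; no single-place step connects it to compound 2.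

Compound 4 `OCCC(CO)n1cnc2c(Cl)ncnc21` differs from compound 2 by hydroxy in place of hydrogen on a saturated chain carbon, two bonds along the chain from an aromatic nitrogen. Among the compounds with values here, no measured step involves this kind of change, so the step that the limit leaves unreadable from compound 2 to compound 4 is expected to stay within the scatter. Compound 4 is therefore estimated at 60000 nM, within 20000 nM to 200000 nM, most likely again a limit.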

Compound 4, half-maximal inhibitory concentration: > 50000 nM
Compound 4 was reported as a limit (the forecaster's own chance of this, stated with the estimate: 70%); the middle value is on the limit's open side.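

Compound 2 and compound 4 are both reported only as limits, so the step between them cannot be read: the limit of > 50000 nM in this assay, at which 2 of the 4 values shown sit.

Going by these compounds, whether hydroxy in place of hydrogen changes the activity of compound 2 in this assay at all remains open.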